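Swapping a Carbamate Amide for an Imidazolyl Sulfonyl

The source may hold more compounds than are shown below. What is called first, only, known or untested is meant among the compounds shown, and "the series" means these compounds.

Compound 1 `Cn1cncc1CN1CC(N(CC2CCN(C(=O)CNC(=O)OC(C)(C)C)CC2)S(=O)(=O)c2ccccn2)Cc2cc(C#N)ccc21` was measured in an ADME assay on Caco-2 cells (Homo sapiens) for permeability, in the apical to basolateral direction (on this read-out lower numbers stand for lower permeability and higher numbers for higher permeability), and gives 0.5 10^-6 cm/s. Among the three compounds measured so far it holds the second highest number. Its nearest neighbour is compound 3 `Cn1cncc1CN1CC(N(CC2CCN(C(=O)NC(C)(C)C)CC2)S(=O)(=O)c2ccccn2)Cc2cc(C#N)ccc21`, which in this assay gives 0.6 10^-6 cm/s, a step of a 1.2-fold higher number from compound 1 to compound 3 (0.08 log units; within the scatter) that stays within the scatter. Furthest from it is compound 2 `CCS(=O)(=O)N1CCC(CN(C2Cc3cc(C#N)ccc3N(Cc3cncn3C)C2)S(=O)(=O)c2ccccn2)CC1`, which in this assay gives 0.1 10^-6 cm/s.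

Compound 4 `Cn1cnc(S(=O)(=O)N2CCC(CN(C3Cc4cc(C#N)ccc4N(Cc4cncn4C)C3)S(=O)(=O)c3ccccn3)CC2)c1` has not yet been measured. It differs from compound 1 in one place: (1-methyl-1H-imidazol-4-yl)sulfonyl in place of (((tert-butoxycarbonyl)amino)methyl)carbonyl on an amine nitrogen in a ring.

Among the compounds with values here, two measured steps bear on this change. The step of a 5.0-fold lower number from compound 1 to compound 2 (0.70 log units; beyond the scatter) puts an ethylsulfonyl on the same amine nitrogen in a ring, and the step of a 6.0-fold higher number from compound 2 to compound 3 (0.78 log units; beyond the scatter) returns a carbonyl-bearing group to that nitrogen. The change to compound 4 likewise places a sulfonyl group on that nitrogen, so a lower number in this assay is expected, of roughly the size seen in the step from compound 1 to compound 2. For compound 4 the estimated step is a 3.3-fold lower number from compound 1 to compound 4 (0.52 log units; beyond the scatter). Compound 4 is therefore estimated at 0.15 10^-6 cm/s, with an expected range from 0.05 10^-6 cm/s to 0.5 10^-6 cm/s.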

Compound 4, apparent permeability: 0.1 10^-6 cm/s
Beside the measured number, compound 4's estimate is 1.5-fold (0.18 log units) above it; the measured number falls inside the stated range.
By their numbers in this assay, from the lowest: compounds 2 and 4 (each within the scatter of the next); then compounds 1 and 3 (each within the scatter of the next).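

The result shows that, in this assay, the group carried on the sulfonyl sulfur has no visible bearing on the number at this position: 1-methyl-1H-imidazol-4-yl in place of ethyl gives (no change at the digits printed from compound 2 to compound 4 (within the scatter)). A second sulfonyl group on the amine nitrogen in a ring now stands clearly apart from both carbonyl-linked compounds, with (a 5.0-fold lower number from compound 1 to compound 4 (0.70 log units; beyond the scatter)) and (a 6.0-fold lower number from compound 3 to compound 4 (0.78 log units; beyond the scatter)), so the gap seen earlier for ethylsulfonyl alone holds across two quite different sulfonyl groups, one with a five-membered aromatic ring and one with none. Nothing in the data at hand explains why the sulfonyl-linked compounds give the lower numbers.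

The compounds shown leave open whether the low number goes with the sulfonyl link as such, since an acetyl group or a plain secondary amine on this nitrogen would help to settle that. They also leave open whether a sulfonyl group bearing a phenyl ring or a longer alkyl chain would stay with compound 2 and compound 4 in this assay or move toward the carbonyl-linked pair.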